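Hydrogen in Place of Chloro, Tried a Second Time

The source may report more compounds than this note shows. Statements on the series, on what has been measured and on what is new or still open speak of the compounds shown alone.

Compound 1 `COc1ccc2ncc(S(=O)(=O)c3ccc(C)c(Cl)c3)c(N3CCC(C)CC3)c2c1`: 85%
Compound 2 `CC1CCN(c2c(S(=O)(=O)c3cccc(Cl)c3)cnc3cc(Cl)ccc23)CC1`: 92%
Compound 3 `COc1ccc2ncc(S(=O)(=O)c3ccc(C)cc3)c(N3CCC(C)CC3)c2c1`: 90%

In an assay on isolated protein for displacement of a labelled ligand from metabotropic glutamate receptor 5 (Homo sapiens), with a stated time of 60 min, tested at 1 uM (on this read-out lower numbers stand for less inhibition and higher numbers for more inhibition at the one concentration tested (going by the name of the read-out)), compound 1 gives 85% and compound 3 gives 90%. The two differ by hydrogen in place of chloro on an aromatic carbon, and the step of a number 5 percentage points higher from compound 1 to compound 3 (within the scatter) is small. Compound 2 gives 92% in this assay; the difference between its core and the core of compound 1 is not broken down here.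

Compound 4 `CC1CCN(c2c(S(=O)(=O)c3ccccc3)cnc3cc(Cl)ccc23)CC1` has not yet been measured. It differs from compound 2 by hydrogen in place of chloro on an aromatic carbon. Among the compounds with values here, this is the same kind of change as the one from compound 1 to compound 3, but not the same: in compound 1 the chloro sits ortho to a methyl group, whereas in compound 2 no such group stands around the place.

Because the earlier step of a number 5 percentage points higher from compound 1 to compound 3 (within the scatter) stayed within the scatter, the step of no change at the digits printed from compound 2 to compound 4 (within the scatter) is expected to be small as well. On that basis compound 4 is estimated at 92% in this assay, expected to fall between 84% and 98%.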

Compound 4, a percentage reported as inhibition, at one concentration (the size of the read-out at that concentration, not a potency): 93%
For compound 4 the middle estimate is 1 percentage points below the measured one; the measured number falls inside the stated range.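

Hydrogen in place of chloro on an aromatic carbon has now been read on two cores in this assay, and in the new case, 3-chlorophenyl to phenyl, the result is a number 1 percentage points higher from compound 2 to compound 4 (within the scatter). Set beside the earlier case, the two steps do not differ: the same change on two cores in this assay, a number 5 percentage points higher (within the scatter) from compound 1 to compound 3 and a number 1 percentage points higher (within the scatter) from compound 2 to compound 4, 4 percentage points apart, within the scatter of two such steps. Within these two cores the change thus carries over with no step beyond the scatter, but this does not show that it would do so on any other core, and each number gives only the size of the inhibition at the one concentration tested, so nothing is shown about the effect at other concentrations.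

The compounds shown leave open how a nitrile, an amine or a carboxylic acid would read in place of the chloro, since only chloro and hydrogen are compared at that place. They also leave open whether the step would hold on a core carrying a group other than the methoxy of compound 1 or the chloro that stays on the core of compound 2.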